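Benzopyranone amides: aryl swap on the carbonyl carbon

This account rests on a few compounds, and the source may have more. Where it says the series, first, only, none or still open, it means among the compounds named here.

Measured so far:
compound 1 `O=C(Nc1cccc(-c2oc3cc(-c4ccc(F)cc4)ccc3c(=O)c2O)c1)c1ccc(F)cc1` — 16000 nM
compound 2 `Cc1ccccc1C(=O)Nc1cccc(-c2oc3cc(-c4ccc(F)cc4)ccc3c(=O)c2O)c1` — 4910 nM

In a functional assay on MDA-MB-231 cells (Homo sapiens) for antiproliferative activity, read by CCK-8 assay, with a stated time of 72 h (on this read-out lower numbers stand for stronger inhibition and higher numbers for weaker inhibition), compound 2 gives the lowest number of the two, compound 1 sitting a step above it: a 3.3-fold lower number from compound 1 to compound 2 (0.51 log units; beyond the scatter). Compound 3 `O=C(Nc1cccc(-c2oc3cc(-c4ccc(F)cc4)ccc3c(=O)c2O)c1)c1ccc(Br)cc1` differs from compound 2 by a single change: 4-bromophenyl in place of 2-methylphenyl on a carbonyl carbon. Among the compounds with values here, only the step from compound 1 to compound 2 bears on this, and it shows that moving from 4-fluorophenyl to 2-methylphenyl lowered the number modestly. A 4-bromophenyl group resembles the 4-fluorophenyl of compound 1 more closely than the 2-methylphenyl of compound 2, so the expectation for compound 3 is a return toward the number of compound 1, a modest step upward, within the scatter at the lower end. The estimated step is a 2.0-fold higher number from compound 2 to compound 3 (0.31 log units; beyond the scatter). Compound 3 is expected to give 10000 nM in this assay, with a plausible range from 3500 nM to 28000 nM.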

Compound 3, half-maximal inhibitory concentration: 24900 nM
Estimate against measurement, compound 3: 2.5-fold (0.40 log units) below; low and high end bracket the measured number.
By their numbers in this assay, from the lowest: compound 2; then compounds 1 and 3 (each within the scatter of the next).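

In this assay, 4-bromophenyl in place of 2-methylphenyl on the carbonyl carbon takes the number back up (a 5.1-fold higher number from compound 2 to compound 3 (0.71 log units; beyond the scatter)). Bromo in place of fluoro on the aromatic carbon gives no separable change (a 1.6-fold higher number from compound 1 to compound 3 (0.19 log units; within the scatter)), so the two halogen-bearing aryl amides, compound 1 and compound 3, cannot be ordered, and of the three compounds only compound 2, with its 2-methylphenyl, stands apart from both others. Nothing at hand accounts for that difference.

Still open, going by these compounds, is whether the methyl itself or its place on the ring carries the lower number of compound 2, which 4-methylphenyl and 2-fluorophenyl on the same carbonyl carbon would separate. Also open, on these data alone, is whether an aryl group is needed there at all, as against a cyclohexyl group or a short alkyl chain.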